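The source may hold more compounds than are shown below. What is called first, only, known or untested is meant among the compounds shown, and "the series" means these compounds.

Compound 2 `CC(C)C[C@@H](c1nc2ccc(C(=O)O)cc2n1C)N1C(=O)CN(c2ccc(-c3ccccc3)cc2)C1=O` gives 23100 nM in an assay on isolated protein for inhibition of Bile acid receptor (Homo sapiens), read by TR-FRET and LanthaScreen (on this read-out lower numbers stand for stronger inhibition and higher numbers for weaker inhibition), the highest of the two numbers measured; its nearest neighbour, compound 1 `CC(C)C[C@@H](c1nc2ccc(C(=O)O)cc2n1C)N1C(=O)CN(c2ccc(Oc3ccc(Cl)cc3)cc2)C1=O`, gives 2560 nM in this assay. Compound 3 `COc1ccc(Oc2ccc(N3CC(=O)N([C@@H](CC(C)C)c4nc5ccc(C(=O)O)cc5n4C)C3=O)cc2)cc1` differs from compound 2 by 4-methoxyphenoxy in place of phenyl on an aromatic carbon. Within the data shown here, the single measured step that bears on this change is a 9.0-fold higher number from compound 1 to compound 2 (0.96 log units; beyond the scatter), in which 4-chlorophenoxy gave the lower number than phenyl. Because compound 1 gives 2560 nM, a return to a phenoxy group in compound 3 is expected to move the number back down, a step estimated as a 5.8-fold lower number from compound 2 to compound 3 (0.76 log units; beyond the scatter). Compound 3 is therefore estimated at 4000 nM, with a range from 1500 nM to 12000 nM.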

Compound 3, half-maximal inhibitory concentration: 75300 nM
The estimate for compound 3 lay 19-fold (1.27 log units) below the measured number, and the stated range ends below it.
By their numbers in this assay, from the lowest: compound 1; then compound 2; then compound 3.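

In this assay, a phenoxy group at this position does not by itself lower the number: 4-methoxyphenoxy in place of phenyl gives a 3.3-fold higher number from compound 2 to compound 3 (0.51 log units; beyond the scatter). The group carried on the phenoxy ring matters greatly, since methoxy in place of chloro gives a 29-fold higher number from compound 1 to compound 3 (1.47 log units; beyond the scatter), which places the two phenoxy groups on opposite sides of the phenyl group. No measurement on hand accounts for this difference.

The compounds shown leave open where unsubstituted phenoxy would fall. They also leave open how a fluoro, methyl or amine group would compare with chloro and methoxy on that ring.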